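Cyclobutyl to Oxolanyl on an Amide Carbonyl

The compounds below may be only part of what the source reports. "The series", "measured", "known", "first", "only" and "open" are said of these compounds alone.

Compound 1 `CCn1c(-c2cnc(C)nc2)nc2c(O[C@H]3CCN(C(=O)C4CC4)C3)ncnc21`: 1.8 h
Compound 2 `CCn1c(-c2cnc(C)nc2)nc2c(O[C@H]3CCN(C(=O)C4CCC4)C3)ncnc21`: 0.3 h
Compound 3 `CCn1c(-c2ccc(C(F)(F)F)nc2)nc2c(O[C@H]3CCN(C(=O)C4CC4)C3)ncnc21`: 0.7 h

These three compounds share one core and were tested in an ADME assay (Rattus norvegicus, strain Wistar Han) for metabolic stability; a lower number here means that the compound disappears faster, a higher number that the compound lasts longer. Compound 2 gives the lowest of the three numbers; compound 3 stands nearest and compound 1 furthest, both beyond the scatter. Compound 4 `CCn1c(-c2cnc(C)nc2)nc2c(O[C@H]3CCN(C(=O)C4CCOC4)C3)ncnc21` differs from compound 2 only at the carbonyl carbon: oxolan-3-yl in place of cyclobutyl on a carbonyl carbon. Among the measured compounds shown here, the one measured step at this place is a 6.0-fold lower number from compound 1 to compound 2 (0.78 log units; beyond the scatter), which shows that the ring on the carbonyl carbon can move the number well beyond the scatter. The step of a 2.6-fold lower number from compound 1 to compound 3 (0.41 log units; beyond the scatter) lies elsewhere and does not bear directly. The expected step is a 2.0-fold higher number from compound 2 to compound 4 (0.30 log units; within the scatter), a modest rise. Compound 4 is therefore estimated at 0.6 h, within 0.2 h to 1.8 h.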

Compound 4, half-life: 1.4 h
Beside the measured number, compound 4's estimate is 2.3-fold (0.37 log units) below it, within the range that was stated.
By their numbers in this assay, from the lowest: compound 2; then compounds 3, 4 and 1 (each within the scatter of the next, the first and the last beyond it).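

Oxolan-3-yl in place of cyclobutyl on this carbonyl carbon gives (a 4.7-fold higher number from compound 2 to compound 4 (0.67 log units; beyond the scatter)), so the low number of compound 2 is not set by the shared core alone. Oxolan-3-yl in place of cyclopropyl gives (a 1.3-fold lower number from compound 1 to compound 4 (0.11 log units; within the scatter)), a step within the scatter, so among these three rings only cyclobutyl stands apart. Nothing shown gives a reason for this difference.

The change from cyclobutyl to oxolan-3-yl enlarges the ring and brings in an oxygen together, and the compounds shown do not separate these two changes. A cyclopentyl group at this place would compare directly with oxolan-3-yl, differing only by that oxygen.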